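Swapping a Side-Chain Branch for a Bulky Ester

The source may hold more compounds than are shown below. What is called first, only, known or untested is meant among the compounds shown, and "the series" means these compounds.

Measured compounds:
Compound 1, `CC(C)[C@@H](NS(=O)(=O)Cc1ccccc1)C(=O)N1CCC[C@H]1C(=O)NCc1ccc(C(=N)N)cc1`: in an assay on isolated protein for inhibition of transmembrane protease serine 11D (Homo sapiens), read by fluorescence (on this read-out higher numbers stand for weaker inhibition and lower numbers for stronger inhibition), compound 1 gives 76 nM.
Compound 2, `CC[C@H](C)[C@H](NCc1ccc(C(=N)N)cc1)C(=O)[C@@H](CCCNC(=N)N)NS(=O)(=O)Cc1ccccc1`: in this assay compound 2 gives 23 nM.
Compound 3, `CC(C)C[C@H](NCc1ccc(C(=N)N)cc1)C(=O)[C@@H](CCCNC(=N)N)NS(=O)(=O)Cc1ccccc1`: in this assay compound 3 gives 47 nM.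

Among these three numbers compound 3 stands second highest. Its gap to compound 1 lies within the scatter, so no order between those two can be read. Compound 2 differs from compound 3 at a single place, and that step, a 2.0-fold higher number from compound 2 to compound 3 (0.31 log units; beyond the scatter), is a modest change beyond the scatter.

Compound 4, `CC(C)(C)OC(=O)C[C@H](NCc1ccc(C(=N)N)cc1)C(=O)[C@@H](CCCNC(=N)N)NS(=O)(=O)Cc1ccccc1`, is the next step from compound 3: tert-butoxycarbonyl in place of isopropyl on a saturated chain carbon, two bonds along the chain from an amine nitrogen and a carbonyl carbon. Going by the values given here, the only measured step that bears on it is the one just named, which alters the same side chain of the shared core and shifted the number modestly. Among the compounds with values here, no measured compound carries an ester at this place, so the direction is uncertain. A modest change is therefore expected, leaning toward a weaker inhibition, as a 1.5-fold higher number from compound 3 to compound 4 (0.17 log units; within the scatter). Compound 4 is estimated at 70 nM, with a range from 20 nM to 250 nM.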

Compound 4, inhibition constant: 512 nM
Estimate against measurement, compound 4: 7.3-fold (0.86 log units) below; measured number above the stated range.
By their numbers in this assay, from the lowest: compound 2; then compounds 3 and 1 (each within the scatter of the next); then compound 4.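

The earlier swap of sec-butyl for isobutyl moved the number only modestly, a 2.0-fold higher number from compound 2 to compound 3 (0.31 log units; beyond the scatter), so this side chain seemed to allow some change. The ester shows that its tolerance has a clear limit in this assay: tert-butoxycarbonyl in place of isopropyl gives an 11-fold higher number from compound 3 to compound 4 (1.04 log units; beyond the scatter), and (tert-butoxycarbonyl)methyl in place of sec-butyl gives a 22-fold higher number from compound 2 to compound 4 (1.35 log units; beyond the scatter), both large steps toward weaker inhibition. No measurement here accounts for the size of this drop.

The compounds shown leave open whether the weaker inhibition follows from the ester carbonyl, the tert-butyl end or simply the larger number of heavy atoms. A carboxylic acid or a methyl ester at this place, and a longer unbranched carbon chain, would help to tell these apart.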